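Methylsulfonylphenyl Analogue Tested Against a Cytotoxicity Ceiling

A few compounds are considered here, and "the series" means these few. Any claim that something is new, unique, unknown or untested is made for them only; others in the source may bear on it.

Compound 1 `CC(C)N(Cc1cccc(OCCCCCC(=O)O)c1)C(=O)c1ccc(-c2ccc3[nH]ccc3c2)cc1` in an ADME assay on BJ cells (Homo sapiens) for cytotoxicity, read by CellTiter-Glo and resazurin assay, with a stated time of 72 h (a higher number here means that more compound is needed for the effect, a lower number that less compound is needed), gives > 26000 nM.
Compound 2 `COc1cc(OC)cc(-c2ccc(C(=O)N(Cc3cccc(OCCCCCC(=O)O)c3)C(C)C)cc2)c1` in this assay gives > 26000 nM.
Compound 3 `CC(C)N(Cc1cccc(OCCCCCC(=O)O)c1)C(=O)c1ccc(-c2cccc(C(F)(F)F)c2)cc1` in this assay gives > 26000 nM.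

Each of these three readings is a limit of the assay rather than a measured number, which is the whole of the evidence so far: the limit of > 26000 nM in this assay, at which 3 of the 3 values shown sit. Compound 1 therefore stands nowhere in particular on the scale; it is only known to sit at the limit, and so do the two compounds beside it.

The compound not yet measured is compound 4 `CC(C)N(Cc1cccc(OCCCCCC(=O)O)c1)C(=O)c1ccc(-c2cccc(S(C)(=O)=O)c2)cc1`. It differs from compound 1 in one place: 3-(methylsulfonyl)phenyl in place of 1H-indol-5-yl on an aromatic carbon.

The two changes already made at that same position are the nearest guides. Both came out as a step that the two limits leave unreadable from compound 1 to compound 2 and a step that the two limits leave unreadable from compound 1 to compound 3, so neither gives a readable size or direction. Nothing measured here distinguishes one group at that position from another, and nothing points to compound 4 behaving differently.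

The expectation for compound 4 in this assay is therefore a step that the limit leaves unreadable from compound 1 to compound 4, most likely again reported as a limit. The estimate for compound 4 is 35000 nM, with a range from 15000 nM to 120000 nM.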

Compound 4, half-maximal effective concentration: > 26000 nM
Compound 4: no number, only a limit; the forecaster's own chance of this, stated with the estimate: 85%; the middle value is on the limit's open side.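

In this assay compound 4 gives > 26000 nM as a limit and not a number. Its steps from compound 1, compound 2 and compound 3 therefore cannot be read: the limit of > 26000 nM in this assay, at which 4 of the 4 values shown sit. The compounds shown leave open how far any of the four lies from that limit, and whether the group at this position changes the reading at all.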